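Benzisoselenazolone-thiadiazole series: halogen swap at the phenyl ring

This account rests on a few compounds, and the source may have more. Where it says the series, first, only, none or still open, it means among the compounds named here.

Measured so far:
compound 1, `O=c1c2ccccc2[se]n1-c1nnc(-c2ccc(Br)cc2)s1`, 68200 nM
compound 2, `O=c1c2ccccc2[se]n1-c1nnc(-c2cc([N+](=O)[O-])cc([N+](=O)[O-])c2)s1`, 21600 nM
compound 3, `O=c1c2ccccc2[se]n1-c1nnc(-c2ccccc2[N+](=O)[O-])s1`, 22500 nM

In a functional assay on SSMC-7721 cells (Homo sapiens) for antiproliferative activity, read by CCK-8 assay, with a stated time of 48 h (a higher number here means a weaker inhibitor, a lower number a stronger inhibitor), compound 1 gives the highest number of the three and is the weakest inhibitor here, since its gaps to compound 2 and compound 3 both lie beyond the usual scatter. Compound 2 and compound 3 give numbers that sit within the scatter of one another, so nothing separates them.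

Compound 4, `O=c1c2ccccc2[se]n1-c1nnc(-c2ccc(F)cc2)s1`, differs from compound 1 by fluoro in place of bromo on an aromatic carbon, placed para to a large group. For the measured compounds named here, no step between measured compounds isolates this change, so no measured pair supports a direction. The swap is expected to give at most a small step in this assay, not beyond the scatter. The expected step of a 1.4-fold lower number from compound 1 to compound 4 (0.13 log units; within the scatter) is estimated to be slight. Compound 4 is therefore expected at 50000 nM, with a range from 20000 nM to 130000 nM.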

Compound 4, half-maximal inhibitory concentration: 42900 nM
Estimate against measurement, compound 4: 1.2-fold (0.07 log units) above; low and high end bracket the measured number.
By their numbers in this assay, from the lowest: compounds 2, 3, 4 and 1 (each within the scatter of the next, the first and the last beyond it).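

In this assay, for the compounds shown here, the change from 4-bromophenyl to 4-fluorophenyl gives a 1.6-fold lower number from compound 1 to compound 4 (0.20 log units; within the scatter), the first comparison that isolates a single place. At this position, exchanging one halogen for the other therefore does not separate the two compounds. No measurement on hand bears on the reason for this result.

Still open, going by these compounds, is what an amine, a carboxylic acid or a methoxy group at this place would do, and whether any replacement for bromo here gives a step beyond the scatter.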